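The compounds below may be only part of what the source reports. "The series", "measured", "known", "first", "only" and "open" are said of these compounds alone.

Measured so far:
Compound 1, `COc1ccc2[nH]c3c(c2c1)CCNC31CCN(Cc2ccc([N+](=O)[O-])cc2F)CC1`: 5900 nM
Compound 2, `COc1ccc2[nH]c3c(c2c1)CCNC31CCN(Cc2ccccc2Cl)CC1`: 2200 nM

Both values come from an assay on FRT cells for positive allosteric modulation of Cystic fibrosis transmembrane conductance regulator variant N1303K (Homo sapiens), in the presence of a further agent that is not named here; on this read-out higher numbers stand for an effect only at larger amounts of compound and lower numbers for an effect already at smaller amounts. Among the compounds with values here, compound 2, with its 2-chlorophenyl group, has the lower of the two numbers; the only neighbour is compound 1, and the step of a 2.7-fold lower number from compound 1 to compound 2 (0.43 log units; beyond the scatter) separates them beyond the scatter, so compound 2 stands as the stronger of the two measured compounds.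

Compound 3, `COc1ccc2[nH]c3c(c2c1)CCNC31CCN(Cc2ccc(Br)cc2F)CC1`, has not yet been measured. Against compound 2 the change is 4-bromo-2-fluorophenyl in place of 2-chlorophenyl on a saturated chain carbon bound to an amine nitrogen in a ring. Within the data shown here, only one measured step bears on this change: a 2.7-fold lower number from compound 1 to compound 2 (0.43 log units; beyond the scatter), which compares compound 1, a 2-fluoro-4-nitrophenyl, with compound 2. Compound 3 returns to a ring that carries a fluorine in the same place as in compound 1 together with a second substituent in the same place as the nitro group there, now a bromine. Among the measured compounds shown here, the single step gives no measure of bromine against nitro, so the expectation is that compound 3 falls between compound 1 and compound 2, with a modest rise in the number estimated as a 1.6-fold higher number from compound 2 to compound 3 (0.20 log units; within the scatter). Compound 3 is therefore expected to give 3500 nM, within a range from 1500 nM to 8000 nM.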

Compound 3, half-maximal effective concentration: 1600 nM
Beside the measured number, compound 3's estimate is 2.2-fold (0.34 log units) above it; the measured number falls inside the stated range.
By their numbers in this assay, from the lowest: compounds 3 and 2 (each within the scatter of the next); then compound 1.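

Bromo in place of nitro on an aromatic carbon, with the rest of the structure unchanged, gives a 3.7-fold lower number from compound 1 to compound 3 (0.57 log units; beyond the scatter), and this is the first step in the series confined to that single substituent. The change from 2-chlorophenyl to 4-bromo-2-fluorophenyl on a saturated chain carbon bound to an amine nitrogen in a ring gives a 1.4-fold lower number from compound 2 to compound 3 (0.14 log units; within the scatter), so in this assay these two groups cannot be told apart, and compound 1 alone stands apart from the other two compounds, with the higher number. Nothing measured here accounts for either step.

As far as these compounds go, because chlorine, fluorine and bromine all change together from compound 2 to compound 3, the share of each halogen in the result stays open, as does how an unsubstituted phenyl or a phenyl carrying bromine alone would compare. From the compounds shown here alone, it also remains open how an amine or a carboxylic acid on the aromatic ring, a longer chain in place of the benzyl link, or any change to the shared core would read in this assay.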